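A few compounds are considered here, and "the series" means these few. Any claim that something is new, unique, unknown or untested is made for them only; others in the source may bear on it.

Measured so far:
compound 1, `CCCCNC(=O)c1c(O)c2cccnc2n(-c2ccccc2)c1=O`, 20.4% 
compound 2, `COc1ccccc1NC(=O)c1c(O)c2cccnc2n(-c2ccccc2)c1=O`, -10.1% 

Both numbers come from a functional assay on the whole organism for inhibition, with Rattus norvegicus as the target, read by cytopathic effect and paw edema, at a dose of 100 mg/kg by the oral route; a higher number here means more inhibition at the dose given (going by the name of the read-out), a lower number less inhibition. Compound 2 stands lowest of the two; its nearest neighbour, compound 1, is higher by a step beyond the scatter. Among the measured compounds shown here, the only single-point step available is a number 30.5 percentage points lower from compound 1 to compound 2 (beyond the scatter), where an aryl amide replaces an alkyl amide and the read-out falls well past the scatter.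

Compound 3, `Cc1cnccc1NC(=O)c1c(O)c2cccnc2n(-c2ccccc2)c1=O`, is not yet measured. Its change from compound 2 is 3-methylpyridin-4-yl in place of 2-methoxyphenyl on an amide-type nitrogen. Here one aryl amide gives way to another aryl amide; the hetero atom count of the entering ring changes, but no measured pair in this series shows what a pyridinyl on the amide nitrogen does. The step from compound 1 to compound 2 bears only indirectly: it shows that the aryl amide of compound 2 sits at the low end, and gives no reason to expect a return toward compound 1. For compound 3 the expected step is a number 8.1 percentage points higher from compound 2 to compound 3 (within the scatter), not beyond the scatter. Compound 3 is estimated at -2%, range -25% to 22%.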

Compound 3, a percentage reported as inhibition, in the whole organism at one dose (the size of the read-out at that dose, not a potency): 8.8%
For compound 3 the middle estimate is 10.8 percentage points below the measured one; the range from low to high includes it.
By their numbers in this assay, from the lowest: compound 2; then compound 3; then compound 1.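

In this assay, the aromatic amides do not all read alike: 3-methylpyridin-4-yl in place of 2-methoxyphenyl on the amide-type nitrogen gives a number 18.9 percentage points higher from compound 2 to compound 3 (beyond the scatter), so the choice of ring at this position matters as well as the contrast between aromatic and alkyl groups. The butyl amide still stays on top, with a number 11.6 percentage points lower from compound 1 to compound 3 (beyond the scatter), and among these three compounds both aromatic groups read lower than butyl, with no compound going against that order. No measurement at hand accounts for either step.

The compounds shown leave open whether the rise from compound 2 to compound 3 belongs to the ring nitrogen, the methyl or the loss of the methoxy group, as all three change in the same step. They also leave open how a plain phenyl, a pyridin-4-yl without the methyl, a longer chain such as hexyl, or a butyl chain ending in an amine or a carboxylic acid would read at this nitrogen.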